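The compounds below may be only part of what the source reports. "The series", "measured", "known", "first", "only" and "open" are said of these compounds alone.

Measured in an in vitro functional assay on cells for agonist activity at Bombesin receptor subtype-3 (Homo sapiens), read by luminescence and calcium flux; on this read-out higher numbers stand for an effect only at larger amounts of compound and lower numbers for an effect already at smaller amounts:
compound 1 `O=C(O)c1ccccc1-c1ccc(CCc2ncc(CC3CCOCC3)[nH]2)cc1` — 338 nM
compound 2 `O=C(O)c1ccccc1-c1ccc(CCc2ncc(Cc3cccc(Cl)c3)[nH]2)cc1` — 825 nM
compound 3 `CC(C)(C)Cc1cnc(CCc2ccc(-c3ccccc3C(=O)O)cc2)[nH]1` — 106 nM

Compound 2 stands highest of the three in this assay: compound 1 is nearest, a 2.4-fold higher number from compound 1 to compound 2 (0.39 log units; beyond the scatter), and compound 3 furthest, a 7.8-fold lower number from compound 2 to compound 3 (0.89 log units; beyond the scatter), both beyond the scatter. Compound 4 `O=C(O)c1ccccc1-c1ccc(CCc2ncc(Cc3cccc(F)c3F)[nH]2)cc1` differs from compound 2 at a single place: 2,3-difluorophenyl in place of 3-chlorophenyl on a saturated chain carbon bound to an aromatic carbon Neither measured step exchanges one aryl group for another; both steps that touch compound 2 leave the 3-chlorophenyl altogether, so they give no direction for 2,3-difluorophenyl in place of 3-chlorophenyl. The step expected in this assay is a 1.0-fold lower number from compound 2 to compound 4 (0.01 log units; within the scatter), which is to say none beyond the scatter. Compound 4 is estimated at 800 nM, within 300 nM to 2500 nM.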

Compound 4, half-maximal effective concentration: 87 nM
Estimate against measurement, compound 4: 9.2-fold (0.96 log units) above, outside the stated range (below it).
By their numbers in this assay, from the lowest: compounds 4 and 3 (each within the scatter of the next); then compound 1; then compound 2.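

In this assay the aryl group on this saturated chain carbon is not tied to the high number of compound 2: 2,3-difluorophenyl in place of 3-chlorophenyl gives a large step (a 9.5-fold lower number from compound 2 to compound 4 (0.98 log units; beyond the scatter)). With 2,3-difluorophenyl, an aromatic ring at this place reads level with tert-butyl (a 1.2-fold lower number from compound 3 to compound 4 (0.09 log units; within the scatter)) and lower than oxan-4-yl (a 3.9-fold lower number from compound 1 to compound 4 (0.59 log units; beyond the scatter)). No supporting data bear on the reason for the step.

On these data alone, whether both fluorines are needed remains open, as a single fluorine or an unsubstituted phenyl would be required to separate them. As far as these compounds go, how an amine or a longer chain would read at this place also remains open.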